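The compounds below may be only part of what the source reports. "The series", "measured", "known", "first", "only" and "open" are said of these compounds alone.

Values so far in a functional assay on PC-3 cells (Homo sapiens) for cytotoxicity, read by MTT assay, with a stated time of 48 h; a higher number here means a weaker inhibitor, a lower number a stronger inhibitor:
- Compound 1 `CC1(C)CCC[C@]2(C)[C@@H](CC[C@@](C)(O)/C=C/c3ccccc3)[C@](C)(O)CC[C@@H]12` gives 121 nM
- Compound 2 `CC1(C)CCC[C@]2(C)[C@@H](CC[C@@](C)(O)/C=C/c3cccc([N+](=O)[O-])c3)[C@](C)(O)CC[C@@H]12` gives 153 nM
- Compound 3 `Cc1cccc(C)c1/C=C/[C@](C)(O)CC[C@@H]1[C@@]2(C)CCCC(C)(C)[C@@H]2CC[C@@]1(C)O` gives 278 nM

Compound 3 lies within the scatter of one of the other two, as shown by a 1.8-fold higher number from compound 2 to compound 3 (0.26 log units; within the scatter). It is separated from the other by a 2.3-fold higher number from compound 1 to compound 3 (0.36 log units; beyond the scatter).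

Compound 4 `CC1(C)CCC[C@]2(C)[C@@H](CC[C@@](C)(O)/C=C/c3ccc(Br)cc3)[C@](C)(O)CC[C@@H]12` carries 4-bromophenyl in place of 2,6-dimethylphenyl on a double-bonded chain carbon bound to a double-bonded chain carbon. No bromine-bearing ring has been measured, so the nearest guides are the two compounds without 2,6-dimethylphenyl. Those two differ only by a 1.3-fold higher number from compound 1 to compound 2 (0.10 log units; within the scatter), and compound 4 is expected to read with them. The two steps into compound 3 then suggest a small move toward a lower number in this assay, of about their size. The estimated step is a 1.9-fold lower number from compound 3 to compound 4 (0.27 log units; within the scatter). The estimated value for compound 4 is 150 nM, with an expected range from 70 nM to 320 nM.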

Compound 4, half-maximal inhibitory concentration: 41300 nM
Compound 4: the middle estimate sits 280-fold (2.44 log units) below what was measured; measured number outside the range, above it.
By their numbers in this assay, from the lowest: compounds 1, 2 and 3 (each within the scatter of the next, the first and the last beyond it); then compound 4.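

In this assay, going by these compounds alone, this position had so far taken changes with little effect, but adding a bromine to the phenyl ring gives a 340-fold higher number from compound 1 to compound 4 (2.53 log units; beyond the scatter) and so shows that the ring on the double-bonded chain carbon can decide the reading, whereas adding a nitro group to that ring gave only a 1.3-fold higher number from compound 1 to compound 2 (0.10 log units; within the scatter) and stayed within the scatter. The change is just as large against the other two rings, with a 270-fold higher number from compound 2 to compound 4 (2.43 log units; beyond the scatter) and a 150-fold higher number from compound 3 to compound 4 (2.17 log units; beyond the scatter), which sets 4-bromophenyl apart from phenyl, 3-nitrophenyl and 2,6-dimethylphenyl alike. Nothing available here accounts for this loss.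

The compounds shown leave open whether the loss goes with the bromine or with any group placed as it is in 4-bromophenyl. 3-Bromophenyl, 4-chlorophenyl or 4-methoxyphenyl in the same place would tell these apart.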